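From Compound 3 to Compound 4: A Changed Phenyl Group

This account rests on a few compounds, and the source may have more. Where it says the series, first, only, none or still open, it means among the compounds named here.

Of the compounds shown here, three built on a shared core have been tested in a functional assay on HepG2 cells (Homo sapiens) for antiproliferative activity, read by MTT assay, with a stated time of 24 h; a higher number here means a weaker inhibitor, a lower number a stronger inhibitor. Compound 1 `O=c1[nH]cc(S(=O)(=O)Nc2ccccc2-c2cn(-c3ccccc3F)nn2)c(=O)[nH]1` gives 12500 nM in this assay. Among the compounds with values here, compound 2 `O=c1[nH]cc(S(=O)(=O)Nc2ccccc2-c2cn(-c3ccc(Cl)cc3)nn2)c(=O)[nH]1` gives 1840 nM, and the single change between them, a 6.8-fold lower number from compound 1 to compound 2 (0.83 log units; beyond the scatter), is the only measured step so far. Compound 3 `Cc1ccccc1-n1cc(-c2cccc(NS(=O)(=O)c3c[nH]c(=O)[nH]c3=O)c2)nn1` gives 9570 nM, the second highest of the three numbers; its value and that of compound 1 lie within the usual scatter of each other, while compound 2 sits clearly below both.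

Compound 4 `O=c1[nH]cc(S(=O)(=O)Nc2cccc(-c3cn(-c4ccc(F)cc4)nn3)c2)c(=O)[nH]1` has not yet been measured. It differs from compound 3 in one place: 4-fluorophenyl in place of 2-methylphenyl on an aromatic nitrogen. The measured step from compound 1 to compound 2 bears on this, since there too a 2-fluorophenyl gave way to a 4-chlorophenyl on the same aromatic nitrogen, a change of the same kind as that from 2-methylphenyl to 4-fluorophenyl. That step was modest but beyond the scatter and lowered the number. A similar direction, perhaps somewhat smaller, is therefore expected here.

Compound 4 is expected to show a step of a 2.7-fold lower number from compound 3 to compound 4 (0.44 log units; beyond the scatter) in this assay. The estimated value for compound 4 is 3500 nM, with a likely range from 1200 nM to 9500 nM.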

Compound 4, half-maximal inhibitory concentration: > 20000 nM
Compound 4: a limit, no number (the forecaster's own chance of this, stated with the estimate: 3%); at least 5.7-fold (0.75 log units) between middle value and limit.
By their numbers in this assay, from the lowest: compound 2; then compounds 3 and 1 (each within the scatter of the next). At a limit, above all of these: compound 4.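

On the aromatic nitrogen of the five-membered ring, putting 4-fluorophenyl in place of 2-methylphenyl raises the number in this assay, giving an at least 2.0-fold higher number from compound 3 to compound 4 (0.32 log units; beyond the scatter), so a change of phenyl group at this position can weaken activity as well as strengthen it. The earlier step, a 6.8-fold lower number from compound 1 to compound 2 (0.83 log units; beyond the scatter), ran the other way, which shows that the direction is not shared by these two pairs, although the groups exchanged are different and the two pairs also differ from each other elsewhere. The result for compound 4 is a limit and not a number, and how far the step really runs stays unknown: the limit of > 20000 nM in this assay, at which 1 of the 4 values shown sits.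

The groups 2-methylphenyl and 4-fluorophenyl differ both in the kind of group on the phenyl ring and in where it sits, and the compounds shown cannot separate these two changes. Also open, on these data alone, is how this position would respond to a plain phenyl, or to a phenyl carrying an amine or a carboxylic acid.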